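A few compounds are considered here, and "the series" means these few. Any claim that something is new, unique, unknown or untested is made for them only; others in the source may bear on it.

Measured compounds:
Compound 1 `CCSc1ccccc1C1=NC(c2ccccc2)CO1`: 4.04
Compound 2 `COc1cccc(C2=NC(c3ccccc3)CO2)c1`: 3.77

Going by the values given here, in a physicochemical assay for lipophilicity (on this read-out higher numbers stand for higher lipophilicity and lower numbers for lower lipophilicity), compound 1 gives 4.04, the higher-placed of the two numbers so far. Compound 2 gives 3.77, and the gap between these two values lies within the usual scatter of this assay, so the two values do not separate from one another. Among the compounds with values here, the two measured compounds share a core but differ in more than one place, so no single-point step between measured compounds is available.

Compound 3 `FC(F)(F)c1ccccc1C1=NC(c2ccccc2)CO1` has not yet been measured in this assay. Against compound 1 its structure differs as follows: trifluoromethyl in place of ethylsulfanyl on an aromatic carbon. Within the data shown here, the data hold no measured example of this particular change.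

From compound 1 to compound 3 a step of a number 0.14 log units lower from compound 1 to compound 3 (within the scatter) is expected, a slight downward shift that stays within the scatter of this assay. Compound 3 is therefore estimated at 3.9 in this assay, with a range from 3.5 to 4.3.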

Compound 3, partition coefficient: 3.71
The estimate for compound 3 lay 0.19 log units above the measured number; the measured number falls inside the stated range.
By their numbers in this assay, from the lowest: compounds 3, 2 and 1 (each within the scatter of the next, the first and the last beyond it).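

In this assay, trifluoromethyl in place of ethylsulfanyl on an aromatic carbon, ortho to a large group, gives a number 0.33 log units lower from compound 1 to compound 3 (beyond the scatter), a modest step. This is the first change in a single place among the compounds shown, and it establishes that the read-out at this position differs measurably between these two groups, which the earlier pair, differing in more than one place, could not show. The data contain no measurement that would account for this step, so its origin remains unexplained.

This single step leaves open whether the same change would give a step of similar size at another position on the six-membered aromatic ring or on a different core. Going by these compounds, it also remains open how the read-out in this assay would respond to an amine, a carboxylic acid or a longer chain at this position, and whether such groups would fall in line with ethylsulfanyl and trifluoromethyl or stand apart from both.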